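This account rests on a few compounds, and the source may have more. Where it says the series, first, only, none or still open, it means among the compounds named here.

Measured so far: compound 1 `CC(C)/C(=C1\C(=O)NC(=O)N1C)c1ccc(-c2ccc3cccc(F)c3c2)[nH]c1=O` gives 85 nM in an assay on membranes from Chem-1 cells for displacement of a labelled ligand from prostaglandin E2 receptor EP3 subtype (Homo sapiens), read by scintillation counting, with a stated time of 2 h; on this read-out higher numbers stand for weaker inhibition and lower numbers for stronger inhibition; compound 2 `O=C1NC(=O)/C(=C/C(c2ccc(-c3ccc4cccc(F)c4c3)[nH]c2=O)C2CC2)O1` gives 22 nM.

Compound 2 has the lower of the two numbers, and the gap to compound 1 lies beyond the usual scatter. Compound 3 `O=C1NC(=O)/C(=C/C(c2ccccc2)c2ccc(-c3ccc4cccc(F)c4c3)[nH]c2=O)O1` has not been measured. It differs from compound 2 in one place: phenyl in place of cyclopropyl on a saturated chain carbon bound to an aromatic carbon and a double-bonded chain carbon. Among the measured compounds shown here, no measured pair shows this change, so the direction of the step is open; a small change is expected, within or near the scatter, toward a somewhat higher number. The step from compound 2 to compound 3 is estimated at a 1.6-fold higher number from compound 2 to compound 3 (0.20 log units; within the scatter). Compound 3 is therefore expected to give about 35 nM, with a range of 10 nM to 120 nM.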

Compound 3, inhibition constant in the prostaglandin E2 receptor EP3 subtype assay: 23 nM
The estimate for compound 3 lay 1.5-fold (0.18 log units) above the measured number; measured number inside the range.
By their numbers in the prostaglandin E2 receptor EP3 subtype assay, from the lowest: compounds 2 and 3 (each within the scatter of the next); then compound 1.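

In the prostaglandin E2 receptor EP3 subtype assay, phenyl in place of cyclopropyl on this saturated chain carbon gives a 1.0-fold higher number from compound 2 to compound 3 (0.02 log units; within the scatter), so this place accepts a ring of 6 heavy atoms as readily as one of 3. In a physicochemical assay for solubility, measured as kinetic solubility, at pH 2 (a lower number here means a less soluble compound, a higher number a more soluble compound), compound 2 gives 3850 nM and compound 3 gives 15400 nM. The same change therefore leaves the receptor read-out level but separates the two compounds in solubility: the measured solubility of compound 2, 3850 nM, and of compound 3, 15400 nM, a 4.0-fold higher number (0.60 log units; beyond the scatter).

As far as these compounds go, how an amine, a carboxylic acid or a longer chain would behave on this carbon stays open. A single pair also cannot show whether this solubility step would recur on another core.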